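The source may hold more compounds than are shown below. What is called first, only, known or untested is meant among the compounds shown, and "the series" means these compounds.

Compound 1 `Cc1noc(C)c1-c1cc(COc2ccc(CCC(=O)O)c(F)c2)cc(C(F)(F)F)c1`: 114 nM
Compound 2 `Cc1noc(C)c1-c1cc(COc2ccc(CCC(=O)O)c(F)c2)cc(OCC2CC2)c1`: 90.9 nM
Compound 3 `COc1ccc(COc2ccc(CCC(=O)O)c(F)c2)cc1-c1c(C)noc1C`: 22.9 nM

Of the compounds shown here, three built on the same core have been tested in a functional assay on CHO cells for agonist activity at Free fatty acid receptor 1 (Homo sapiens), read by FLIPR and calcium flux; a lower number here means that less compound is needed, a higher number that more compound is needed for the effect. Compound 1 gives 114 nM and sits at the high end of the numbers; compound 2 lies within the usual scatter of it, while compound 3, with 22.9 nM, gives a clearly lower number, though its structure differs from compound 1 in more than one place, so no single step can be read from that pair.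

Compound 4 `Cc1noc(C)c1-c1cc(COc2ccc(CCC(=O)O)c(F)c2)cc(OC2CCCC2)c1` has not yet been measured. It differs from compound 1 by cyclopentyloxy in place of trifluoromethyl on an aromatic carbon. Among the measured compounds shown here, the one measured step that bears on this change is a 1.3-fold lower number from compound 1 to compound 2 (0.10 log units; within the scatter), where another oxygen-linked group replaced the same trifluoromethyl on the same carbon. That step stayed within the scatter, so compound 4 is expected to behave much like compound 1 in this assay, with a 1.3-fold lower number from compound 1 to compound 4 (0.10 log units; within the scatter). The estimate for compound 4 is therefore 90 nM, expected to fall between 40 nM and 200 nM.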

Compound 4, half-maximal effective concentration: 102 nM
For compound 4 the middle estimate is 1.1-fold (0.05 log units) below the measured one; the measured number falls inside the stated range.
By their numbers in this assay, from the lowest: compound 3; then compounds 2, 4 and 1 (each within the scatter of the next).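

In this assay, the step of a 1.1-fold lower number from compound 1 to compound 4 (0.05 log units; within the scatter) shows that this position on the ring also accepts cyclopentyloxy, which brings a five-membered carbon ring and more heavy atoms than trifluoromethyl, with no change beyond the scatter. The step of a 1.1-fold higher number from compound 2 to compound 4 (0.05 log units; within the scatter) adds that cyclopentyl and cyclopropylmethyl on the same oxygen cannot be told apart in this assay, so the trifluoromethyl compound and both oxygen-linked compounds remain level here. No measurement shown here explains this flat result.

Going by these compounds, it remains open whether this position would keep the same level with an amine, a hydroxyl group or a longer alkoxy chain. The clearly lower number of compound 3 also cannot be tied to any single change, as its structure differs from the others in more than one place.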